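The compounds below may be only part of what the source reports. "The series", "measured", "known", "first", "only" and "open" are said of these compounds alone.

Measured in a physicochemical assay for lipophilicity, using the shake flask method, in phosphate buffer, measured as octanol-water partition, with a stated time of 30 min, at pH 7.4; a lower number here means a more polar compound, a higher number a more lipophilic compound:
- compound 1 `CN(c1ncco1)c1cnc(NCc2c(F)ccc3c2CCO3)n2cnnc12`: 2.1
- compound 2 `Cc1nccn1-c1cnc(NCc2c(F)ccc3c2CCO3)c2cn[nH]c(=O)c12`: 2.1

In this assay compound 1 stands level with compound 2, and the two show no difference beyond the scatter of repeated measurements. Among the compounds with values here, these two compounds form no step that differs in one place, so the series offers no measured guide to the size of the next change.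

The next compound to consider is compound 3 `Fc1ccc2c(c1CNc1ncc(Oc3ccccc3)c3nncn13)CCO2`, which differs from compound 1 on the shared core by phenoxy in place of methyl(1,3-oxazol-2-yl)amino on an aromatic carbon. The change puts phenoxy in place of methyl(1,3-oxazol-2-yl)amino on an aromatic carbon. One five-membered aromatic ring with 2 hetero atoms leaves, and one six-membered aromatic ring of carbon only enters.

From the counted change, and starting from compound 1 at 2.1, a rise in this assay beyond the scatter is expected. Within the data shown here, no measured pair tests this exchange, so the range is kept wide. The expected change is a number 0.90 log units higher from compound 1 to compound 3 (beyond the scatter). The estimate for compound 3 is 3, with an expected range of 2.5 to 3.6.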

Compound 3, distribution coefficient: 3.5
Compound 3: the middle estimate sits 0.50 log units below what was measured; the measured number falls inside the stated range.
By their numbers in this assay, from the lowest: compounds 1 and 2 (each within the scatter of the next); then compound 3.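

In this assay, the position on an aromatic carbon of a six-membered aromatic ring with 2 nitrogen now has its first measured step: phenoxy in place of methyl(1,3-oxazol-2-yl)amino gives a number 1.40 log units higher from compound 1 to compound 3 (beyond the scatter). The heavy-atom count is the same on both sides of this exchange, so the step shows that the reading at this position can move well beyond the scatter without any change in that count; what differs is a five-membered aromatic ring with 2 hetero atoms and its 3 hydrogen-bond acceptors giving way to a six-membered aromatic ring of carbon only and its 1 hydrogen-bond acceptor. Nothing measured here bears on the origin of the step.

This single exchange alters the ring, the linking atom and the acceptor count together, so the share of each in the step remains unresolved. A phenylamino group would hold the ring and change the link, and a pyridin-2-yloxy group would hold the ether oxygen and put a nitrogen into the ring, so either would help divide the step.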